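Compound 3 to compound 4: a change of configuration

This account rests on a few compounds, and the source may have more. Where it says the series, first, only, none or still open, it means among the compounds named here.

Measured in an ADME assay on liver for metabolic stability, with Liver microsome (Homo sapiens) as the target, read by LC-MS, using microsomes; a higher number here means faster removal of the compound, a lower number slower removal:
- compound 1 `O=C(NCc1cc(Cl)ccc1-n1cnnn1)[C@@H]1C[C@@H]2C[C@@H]2N1C(=O)[C@H](O)c1cccc(Cl)c1`: > 500 mL.min-1.g-1 (a limit)
- compound 2 `CC(C)(C)OC[C@@H](O)C(=O)N1[C@H](C(=O)NCc2cc(Cl)ccc2-n2cnnn2)C[C@@H]2C[C@@H]21`: 21 mL.min-1.g-1
- compound 3 `CC(C)(C)C[C@@H](O)C(=O)N1[C@@H]2C[C@@H]2C[C@H]1C(=O)NCc1cc(Cl)ccc1-n1cnnn1`: 71 mL.min-1.g-1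

The value of compound 1 is a limit of this assay, not a number. Compound 2 gives 21 mL.min-1.g-1 and compound 3 gives the higher 71 mL.min-1.g-1, a gap beyond the scatter.

Compound 4 `CC(C)(C)C[C@@H](O)C(=O)N1[C@H](C(=O)NCc2cc(Cl)ccc2-n2cnnn2)C[C@@H]2C[C@@H]21` differs from compound 3 as follows: the two compounds have the same atoms and bonds and differ only in configuration as drawn: 2 of 4 stereo elements differ; a stereocentre at a saturated ring carbon is drawn R in compound 3 and S in compound 4; a stereocentre at a saturated ring carbon is drawn R in compound 3 and S in compound 4.

For the measured compounds named here, the only measured step, an at least 23-fold lower number from compound 1 to compound 2 (1.37 log units; beyond the scatter), is large but exchanges groups and leaves configuration out, so it sets no size for this change. No shift beyond the scatter is therefore expected in this assay, in either direction. The expected step is a 1.3-fold lower number from compound 3 to compound 4 (0.11 log units; within the scatter). Compound 4 is estimated at 55 mL.min-1.g-1, with an expected range of 15 mL.min-1.g-1 to 200 mL.min-1.g-1.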

Compound 4, intrinsic clearance in microsomes: 40 mL.min-1.g-1
Beside the measured number, compound 4's estimate is 1.4-fold (0.14 log units) above it; the range from low to high includes it.
By their numbers in this assay, from the lowest: compounds 2, 4 and 3 (each within the scatter of the next, the first and the last beyond it). At a limit, above all of these: compound 1.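

In this assay, the change of configuration gives a 1.8-fold lower number from compound 3 to compound 4 (0.25 log units; within the scatter), so altering these two ring stereocentres produces no shift beyond the scatter. Tert-butyl in place of tert-butoxy gives a 1.9-fold higher number from compound 2 to compound 4 (0.28 log units; within the scatter), which also stays within the scatter. Neopentyl in place of 3-chlorophenyl gives an at least 12-fold lower number from compound 1 to compound 4 (1.09 log units; beyond the scatter), a large step that rests on a limit rather than a number: the limit of > 500 mL.min-1.g-1 in this assay, at which 1 of the 4 values shown sits.

Still open, as far as these compounds go, is how an amine or a longer chain in place of neopentyl would read in this assay. From the compounds shown here alone, the configuration of the carbon bearing the hydroxyl group also remains open.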